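The source may report more compounds than this note shows. Statements on the series, on what has been measured and on what is new or still open speak of the compounds shown alone.

Compound 1 `CC(C)(C)Cc1c(-c2ccoc2)sc(N)c1C(=O)c1ccc(Cl)cc1`: 1%
Compound 2 `CC(C)(C)Cc1c(/C=C/c2ccc(Cl)cc2)sc(N)c1C(=O)c1ccc(Cl)cc1`: 11%
Compound 3 `Cc1ccc(-c2sc(N)c(C(=O)c3ccc(Cl)cc3)c2CC(C)(C)C)cc1`: 1%

In an assay on CHO cells for displacement of a labelled ligand from adenosine receptor A3 (Homo sapiens), read by scintillation counting, tested at 10 uM (on this read-out lower numbers stand for less inhibition and higher numbers for more inhibition at the one concentration tested (going by the name of the read-out)), compound 3 gives 1%, level with compound 1 at the digits shown, and together with it the lowest of the three numbers. Its nearest neighbour is compound 1, with no change at the digits printed from compound 1 to compound 3 (within the scatter); its furthest is compound 2, with a number 10 percentage points lower from compound 2 to compound 3 (within the scatter). Compound 4 `CC(C)c1ccc(-c2sc(N)c(C(=O)c3ccc(Cl)cc3)c2CC(C)(C)C)cc1` differs from compound 3 in one place: isopropyl in place of methyl on an aromatic carbon. The two measured steps that touch compound 3 are both within the scatter, and no measured pair exchanges methyl for isopropyl, so the data give no reason to expect movement. The step to compound 4 is therefore estimated as a number 1 percentage points higher from compound 3 to compound 4 (within the scatter), no change beyond the scatter. Compound 4 is expected to give 2%, within 0% to 12%.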

Compound 4, a percentage reported as inhibition, at one concentration (the size of the read-out at that concentration, not a potency): 1%
Compound 4: middle estimate off by 1 percentage points, on the high side, and the stated range covers the measured number.
By their numbers in this assay, from the lowest: compounds 1, 3, 4 and 2 (each within the scatter of the next).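

Isopropyl in place of methyl, para to a large group, gives in this assay no change at the digits printed from compound 3 to compound 4 (within the scatter), so the larger alkyl group on this ring adds no measurable inhibition. Against the other groups at this place, the 4-isopropylphenyl group gives no change at the digits printed from compound 1 to compound 4 (within the scatter) and a number 10 percentage points lower from compound 2 to compound 4 (within the scatter), so none of these changes separates from the rest. No evidence on the cause of this flat result is available.

From the compounds shown here alone, it remains open whether an amine or a carboxylic acid in place of the isopropyl would move the number beyond the scatter. The same question holds for a longer chain.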